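The source may report more compounds than this note shows. Statements on the series, on what has been measured and on what is new or still open speak of the compounds shown alone.

Measured so far in a physicochemical assay for solubility, read by chemiluminescence, measured as kinetic solubility; on this read-out higher numbers stand for higher solubility and lower numbers for lower solubility:
- compound 1 `Clc1ccc(CNc2ccnc(N3CCC4(CCN(CC5CCCN5)C4)CC3)n2)c(Cl)c1` gives 270 ug/mL
- compound 2 `O=C(C1CCCN1)N1CCC2(CCN(c3nccc(NCc4ccc(F)cc4F)n3)CC2)C1` gives 175 ug/mL

Repeated measurements of this kind naturally scatter, and these two numbers lie within that scatter. Compound 2 (175 ug/mL) therefore stands level with compound 1 (270 ug/mL), and the two cannot be told apart.

The next molecule is compound 3 `Fc1ccc(CNc2ccnc(N3CCC4(CCN(CC5CCCN5)C4)CC3)n2)c(F)c1`, which has one change from compound 2: (pyrrolidin-2-yl)methyl in place of (pyrrolidin-2-yl)carbonyl on an amine nitrogen in a ring. The count of what leaves and what enters reads (pyrrolidin-2-yl)methyl in place of (pyrrolidin-2-yl)carbonyl on an amine nitrogen in a ring as the full record of that swap.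

Going by the values given here, no measured pair isolates this change, so its size in this assay cannot be read directly from the data. Among the compounds with values here, the only guide is that compound 1, which also carries a (pyrrolidin-2-yl)methyl group, gives 270 ug/mL in the same test. A small upward move is expected, with no step beyond the scatter. The expected step of a 1.4-fold higher number from compound 2 to compound 3 (0.15 log units; within the scatter) is correspondingly modest. For compound 3 the estimated value is 250 ug/mL with an expected range of 120 ug/mL to 450 ug/mL until the measurement arrives.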

Compound 3, solubility: 160 ug/mL
Compound 3: middle estimate off by 1.6-fold (0.19 log units), on the high side; measured number inside the range.
By their numbers in this assay, from the lowest: compounds 3, 2 and 1 (each within the scatter of the next).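

In this assay, going by these compounds alone, the first direct comparison at this position puts (pyrrolidin-2-yl)methyl in place of (pyrrolidin-2-yl)carbonyl on the amine nitrogen in a ring, and it gives a 1.1-fold lower number from compound 2 to compound 3 (0.04 log units; within the scatter) as its step, so here the two groups cannot be told apart from the ordinary difference between repeat measurements. The second comparison, 2,4-difluorophenyl in place of 2,4-dichlorophenyl on a saturated chain carbon bound to a nitrogen on an aromatic ring, gives a 1.7-fold lower number from compound 1 to compound 3 (0.23 log units; within the scatter) as its step, so this swap of one halogen pair for another also stays inside that ordinary difference, and neither change can be given a direction. Nothing available here explains either result.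

These compounds leave open whether a different group on that ring nitrogen, such as a longer chain ending in a carboxylic acid, would move the number beyond the scatter. They also leave open whether a phenyl group carrying methoxy in place of the two halogens would separate clearly from the compounds compared here.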